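A few compounds are considered here, and "the series" means these few. Any claim that something is new, unique, unknown or untested is made for them only; others in the source may bear on it.

For the measured compounds named here, compound 1, `CC(O)(C[S+]([O-])c1ccc(C(F)(F)F)cc1)C(=O)Nc1ccc([N+](=O)[O-])cc1C(F)(F)F`, is one of two compounds measured so far. In a functional assay on CWR22R cells (Homo sapiens) for antiproliferative activity (a lower number here means a stronger inhibitor, a higher number a weaker inhibitor), compound 1 gives 21100 nM. Compound 2, `CC(O)(C[S+]([O-])c1ccc(OC(F)(F)F)cc1)C(=O)Nc1ccc(C#N)c(C(F)(F)F)c1`, gives in this assay a value of 41200 nM. Compound 1 has the lower of the two numbers, but the gap to compound 2 lies within the usual scatter of repeated measurements, so neither can be set above the other; both are weak inhibitors.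

Compound 3, `CC(O)(C[S+]([O-])c1ccccc1OC(F)(F)F)C(=O)Nc1ccc([N+](=O)[O-])cc1C(F)(F)F`, arises from compound 1 by a single change: 2-(trifluoromethoxy)phenyl in place of 4-(trifluoromethyl)phenyl on a sulfur. Going by the values given here, no measured pair of compounds shows what this exchange does, so the expectation rests only on the shared core and on the weak activity of compound 1 at 21100 nM. The expected step of a 1.2-fold higher number from compound 1 to compound 3 (0.07 log units; within the scatter) is small, with no preferred direction, and not beyond the scatter. Compound 3 is therefore estimated at 25000 nM in this assay, with a likely range from 8000 nM to 80000 nM.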

Compound 3, half-maximal inhibitory concentration: 15200 nM
Compound 3: the middle estimate sits 1.6-fold (0.22 log units) above what was measured; measured number inside the range.
By their numbers in this assay, from the lowest: compounds 3, 1 and 2 (each within the scatter of the next, the first and the last beyond it).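

In this assay, putting 2-(trifluoromethoxy)phenyl in place of 4-(trifluoromethyl)phenyl on the sulfur gives a 1.4-fold lower number from compound 1 to compound 3 (0.14 log units; within the scatter), so the two compounds cannot be ranked against each other. For the compounds shown here, this is the first pair here that differs in only one place, and it shows that this position accepts an exchange of one substituted phenyl for another, including one extra oxygen atom, without a change in the read-out beyond the scatter. No separate measurement bears on this result, so it stands as an observation without an explanation.

The exchange alters both the substituent and its number on the ring, so this single pair cannot separate the two, and a group such as 2-(trifluoromethyl)phenyl on the sulfur would be needed to tell them apart. On these data alone, it also remains open whether a quite different group at this position, such as an unsubstituted phenyl, a ring carrying an amine or a carboxylic acid, or a plain alkyl chain, would move the number beyond the scatter in either direction.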